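Swapping tert-butyl for 4-methylphenyl: what to expect

The source may hold more compounds than are shown below. What is called first, only, known or untested is meant among the compounds shown, and "the series" means these compounds.

In a functional assay for inhibition, with Rattus norvegicus as the target (on this read-out higher numbers stand for weaker inhibition and lower numbers for stronger inhibition), compound 1 `CC(/N=c1\c(O)c(O)\c1=N/c1ccc(Br)cc1)C(C)(C)C` gives 1260 nM and compound 2 `CC(/N=c1\c(O)c(O)\c1=N/c1ccc(C#N)cc1)C(C)(C)C` gives 520 nM, the lower of these two numbers. Compound 3 `C[C@H](/N=c1\c(O)c(O)\c1=N/c1ccc(C#N)cc1)c1ccccc1` reads > 30000 nM, which is a limit of the assay. Compound 4 `Cc1ccc(C(C)/N=c2\c(O)c(O)\c2=N/c2ccc(C#N)cc2)cc1` differs from compound 2 by 4-methylphenyl in place of tert-butyl on a saturated chain carbon bound to a double-bonded nitrogen and a saturated chain carbon. Like compound 3, it brings an aromatic ring into this part of the molecule. The step of a 2.4-fold lower number from compound 1 to compound 2 (0.38 log units; beyond the scatter) concerns a different group, so it bears little on this change. The closer guide is the large step of an at least 57-fold higher number from compound 2 to compound 3 (1.76 log units; beyond the scatter). A large upward step is therefore expected in this assay, a 17-fold higher number from compound 2 to compound 4 (1.24 log units; beyond the scatter). For compound 4 the estimated value is 9000 nM, with an expected range of 1800 nM to 30000 nM.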

Compound 4, half-maximal inhibitory concentration: > 30000 nM
Compound 4 ended at the assay's limit (the forecaster's own chance of this, stated with the estimate: 40%); middle value at least 3.3-fold (0.52 log units) away from the limit.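

In this assay, 4-methylphenyl in place of tert-butyl gives an at least 57-fold higher number from compound 2 to compound 4 (1.76 log units; beyond the scatter), so the loss seen with the 1-phenylethyl group of compound 3 is not confined to that one aromatic group. The reading for compound 4 is a limit, not a number. The true size of this step therefore stays unknown, and compound 3 and compound 4 cannot be ranked against each other: the limit of > 30000 nM in this assay, at which 2 of the 4 values shown sit.

Still open, as far as these compounds go, is whether a saturated ring such as cyclohexyl at this place would keep the inhibition of compound 2. That would separate the effect of having a ring from that of having an aromatic one.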